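Adding a Third Methoxy at the Far End

The source may hold more compounds than are shown below. What is called first, only, known or untested is meant among the compounds shown, and "the series" means these compounds.

Three close relatives share one core. Compound 1 `CCOC(=O)COc1cc(-c2cc(=O)c3c(O)cc(OCC(=O)N4CCN(Cc5ccc(OC)cc5)CC4)cc3o2)ccc1OC` carries a single methoxy at the far end of that shared core; in an ADME assay on MRC5 cells (Homo sapiens) for cytotoxicity (a higher number here means a weaker inhibitor, a lower number a stronger inhibitor), compound 1 has "not determined" (no result reported), so it contributes no number. Among the measured compounds shown here, compound 2 `CCOC(=O)COc1cc(-c2cc(=O)c3c(O)cc(OCC(=O)N4CCN(Cc5ccc(OC)cc5OC)CC4)cc3o2)ccc1OC` carries two methoxy groups at that end, and in this assay compound 2 gives 5600 nM, the only number available, with no second measured compound to set it against. Compound 3 `CCOC(=O)COc1cc(-c2cc(=O)c3c(O)cc(OCC(=O)N4CCN(Cc5c(OC)cc(OC)cc5OC)CC4)cc3o2)ccc1OC` is the not yet measured third member. It differs from compound 2 by methoxy in place of hydrogen on an aromatic carbon. For the measured compounds named here, with no measured pair to show how such an addition plays out, the expectation for the step of a 1.1-fold higher number from compound 2 to compound 3 (0.03 log units; within the scatter) is of no movement beyond the usual scatter, in either direction. Compound 3 is therefore estimated at 6000 nM in this assay, with a plausible range from 2500 nM to 15000 nM.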

Compound 3, half-maximal inhibitory concentration: 9500 nM
Compound 3: middle estimate off by 1.6-fold (0.20 log units), on the low side, within the range that was stated.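

In this assay, among the compounds shown here, the step of a 1.7-fold higher number from compound 2 to compound 3 (0.23 log units; within the scatter) gives the first reading of this change. It shows that methoxy in place of hydrogen, on an aromatic carbon ortho to a large group and meta to two methoxy groups, does not take the number beyond the scatter in this single pair. Nothing measured here accounts for the reading. As far as these compounds go, with no number for compound 1, the step from a single methoxy to two cannot be read, so whether each added methoxy behaves alike remains unknown. Also open, from the compounds shown here alone, is whether an amine, a hydroxyl, a fluorine or a longer chain such as ethoxy in place of the third methoxy would move the number beyond the scatter.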